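A few compounds are considered here, and "the series" means these few. Any claim that something is new, unique, unknown or untested is made for them only; others in the source may bear on it.

Compound 1 `CN(C)C(=O)c1cc2cnc(Nc3ccc(S(=O)(=O)NCCCCN=C=S)cc3)nc2n1C1CCCC1`: in a functional assay on A549 cells (Homo sapiens) for inhibition, read by CCK-8 assay, with a stated time of 72 h, tested at 10 uM (on this read-out higher numbers stand for a stronger effect at the one concentration tested and lower numbers for a weaker effect), compound 1 gives 101%.
Compound 2 `CN(C)C(=O)c1cc2cnc(Nc3ccc(NC(=O)CCCCCCN=C=S)cc3)nc2n1C1CCCC1`: in this assay compound 2 gives 102%.

On these two numbers compound 2 stands highest, with compound 1 nearest; the step of a number 1 percentage points higher from compound 1 to compound 2 (within the scatter) keeps both near complete inhibition. Compound 3 `CN(C)C(=O)c1cc2cnc(Nc3ccc(N=C=S)cc3)nc2n1C1CCCC1` differs from compound 2 by a group of 3 heavy atoms (1 carbon, 1 nitrogen, 1 sulfur; no ring) in place of a group of 12 heavy atoms (8 carbon, 2 nitrogen, 1 oxygen, 1 sulfur; no ring), on an aromatic carbon. Within the data shown here, the only measured step swapped one chain for another rather than shortening the chain to a group of 3 heavy atoms, so it bears on this change only loosely, and no measured step lies beyond the scatter. Compound 3 is therefore expected to show a small change, a number 12 percentage points lower from compound 2 to compound 3 (beyond the scatter). The estimate for compound 3 is 90%, with a range from 55% to 103%.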

Compound 3, a percentage reported as inhibition, at one concentration (the size of the read-out at that concentration, not a potency): 97.9%
Estimate against measurement, compound 3: 7.9 percentage points below; measured number inside the range.
By their numbers in this assay, from the lowest: compounds 3, 1 and 2 (each within the scatter of the next).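

Replacing either long chain with the group of 3 heavy atoms gives a number 4.1 percentage points lower from compound 2 to compound 3 (within the scatter) and a number 3.1 percentage points lower from compound 1 to compound 3 (within the scatter) in this assay. On an aromatic carbon para to a large group, the much shorter group therefore holds the read-out level with both chains, so chain length is not shown to matter at this one concentration. No available evidence explains this result.

From the compounds shown here alone, it remains open whether an amine or a carboxylic acid at this position would give a similar reading. Going by these compounds, with all three compounds this close together, whether any of them has a stronger or weaker effect at this one concentration also remains open.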